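Adding a Methoxy Group on Two Different Cores

The source may hold more compounds than are shown below. What is called first, only, known or untested is meant among the compounds shown, and "the series" means these compounds.

All values below come from a functional assay on NCI-H460 cells (Homo sapiens) for inhibition, read by sulforhodamine B assay, with a stated time of 48 h; a lower number here means a stronger inhibitor of growth, a higher number a weaker inhibitor of growth.

Compound 1, `COc1ccc(/C=C/c2cc(=O)cco2)cc1`: 606 uM
Compound 2, `COc1ccc(/C=C/c2cc(=O)cco2)cc1OC`: 546 uM
Compound 3, `COc1ccc(/C=C/C2CC=CC(=O)N2)cc1OC`: > 964 uM

Compound 2 differs from compound 1 by methoxy in place of hydrogen on an aromatic carbon, and this gives a 1.1-fold lower number from compound 1 to compound 2 (0.05 log units; within the scatter). The two values of compound 1 and compound 2 therefore show no difference that can be read as real.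

Compound 3 carries a different core; the difference between the two cores of compound 1 and compound 3 is not broken down here. In this assay compound 3 gives > 964 uM, which is a limit of the assay and not a number; this is the limit of > 964 uM in this assay, at which 1 of the 3 values shown sits.

Compound 4, `COc1cc(OC)c(OC)cc1/C=C/C1CC=CC(=O)N1`, is not yet measured. It differs from compound 3 by methoxy in place of hydrogen on an aromatic carbon. The place is not the same as in the earlier pair: there the entering methoxy sat ortho to a methoxy group and meta to a group of 9 heavy atoms, here it sits ortho to a group of 9 heavy atoms, meta to a methoxy group and para to a methoxy group. It is the same kind of change, not the same change.

Because a 1.1-fold lower number from compound 1 to compound 2 (0.05 log units; within the scatter) lies within the scatter, the step that the limit leaves unreadable from compound 3 to compound 4 is expected to be small as well. Compound 4 is therefore expected to give 1200 uM in this assay, with the estimate spanning 500 uM to 3000 uM, and most likely to return only a limit again, since compound 3 gives > 964 uM.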

Compound 4, concentration for growth inhibition (reported as GI): > 864 uM
Compound 4: a limit, no number; the forecaster's own chance of this, stated with the estimate: 70%; the middle value does not contradict the limit.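

Compound 4 gives > 864 uM, a limit of the assay and not a number. Compound 3 also stands at a limit, > 964 uM. For the compounds shown here, with limits on both sides, no step from compound 3 to compound 4 can be read. The compounds shown leave open whether methoxy in place of hydrogen on an aromatic carbon changes growth inhibition at all on the core of compound 3.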